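Swapping a Saturated Ring for a Bromophenyl Ring

The source may report more compounds than this note shows. Statements on the series, on what has been measured and on what is new or still open speak of the compounds shown alone.

Measured so far:
compound 1 `O=[N+]([O-])c1ccccc1CNc1cc(Br)cc2cn[nH]c12`: 9%
compound 2 `FC(F)(F)c1cc(NC[C@H]2CCCCN2)c2cn[nH]c2c1`: 69%
compound 3 `FC(F)(F)c1cc(NC[C@H]2CCCN2)c2cn[nH]c2c1`: 83%

In an assay for inhibition of Indoleamine 2,3-dioxygenase 1 (Homo sapiens), with stated times of 10 min and 60 min, tested at 100 uM (on this read-out lower numbers stand for a weaker effect and higher numbers for a stronger effect at the one concentration tested), compound 3 gives the highest of the three numbers; compound 2 sits a number 14 percentage points higher from compound 2 to compound 3 (beyond the scatter) below it, and compound 1 is far lower still. Compound 4 `FC(F)(F)c1cc(NCc2cccc(Br)c2)c2cn[nH]c2c1` differs from compound 3 in one place: 3-bromophenyl in place of pyrrolidin-2-yl on a saturated chain carbon bound to a nitrogen on an aromatic ring. Going by the values given here, no measured step covers this kind of change. Compound 1 also carries an aromatic ring on that chain carbon and gives a low value, but it differs from compound 3 in other places too, so it offers only a weak hint. Compound 4 is therefore expected to fall a number 48 percentage points lower from compound 3 to compound 4 (beyond the scatter), with wide uncertainty, to an estimated 35%, between 5% and 75%.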

Compound 4, a percentage reported as inhibition, at one concentration (the size of the read-out at that concentration, not a potency): 51%
For compound 4 the middle estimate is 16 percentage points below the measured one; low and high end bracket the measured number.
By their numbers in this assay, from the lowest: compound 1; then compound 4; then compound 2; then compound 3.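

On the saturated chain carbon bound to a nitrogen on an aromatic ring, 3-bromophenyl in place of pyrrolidin-2-yl gives a number 32 percentage points lower from compound 3 to compound 4 (beyond the scatter), while in place of piperidin-2-yl it gives a number 18 percentage points lower from compound 2 to compound 4 (beyond the scatter). In this assay, both saturated rings therefore outscore this aromatic ring, yet compound 4 keeps 51%, so a ring without nitrogen is tolerated here with only a partial loss. Nothing available explains this drop. The compounds shown leave open whether the bromine or the aromatic ring itself sets this level, and how a plain phenyl ring or an open-chain amine would compare at this place.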